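The source may hold more compounds than are shown below. What is called first, only, known or untested is meant among the compounds shown, and "the series" means these compounds.

Measured compounds:
compound 1, `CCCCC1([C@@H](O)/C=C/C2CCC(=O)[C@@H]2CCCCCCC(=O)OCC)CCC1`: 0.032 mg/kg
compound 2, `CCCCC1([C@H](O)/C=C/C2CCC(=O)[C@@H]2C/C=C\CCCC(=O)O)CCC1`: 0.0022 mg/kg
compound 3, `CCCCC1([C@H](O)/C=C/C2CCC(=O)[C@@H]2C/C=C\CCCC(=O)OCC)CCC1`: 0.221 mg/kg

In a functional assay on the whole organism (strain Hartley) for inhibition, with Cavia porcellus as the target, with stated times of 15 min and 2 min (a higher number here means that more compound is needed for the effect, a lower number that less compound is needed), compound 2 gives the lowest of the three numbers; compound 1 is the nearest of the others and compound 3 the furthest. The unmeasured compound 4, `CCCCC1([C@H](O)/C=C/C2CCC(=O)[C@@H]2CCCCCCC(=O)O)CCC1`, keeps the free carboxylic acid of compound 2 and differs from it only in the chain: 5-carboxypentyl in place of 5-carboxypent-1-en-1-yl on a saturated chain carbon bound to a saturated ring carbon.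

Within the data shown here, one measured step touches this series, a 100-fold higher number from compound 2 to compound 3 (2.00 log units; beyond the scatter), and it concerns the acid against its ethyl ester rather than the chain itself. Among the measured compounds shown here, no step between two measured compounds isolates the change from compound 2 to compound 4. Compound 1 and compound 3 both carry the ethyl ester, and compound 1 with the saturated chain gives the lower number, but the two also differ at the hydroxyl-bearing carbon, so their values can only be read as a loose hint. On this basis compound 4 is expected to stay close to compound 2, with at most a modest step, a 1.4-fold higher number from compound 2 to compound 4 (0.13 log units; within the scatter), in this assay. The estimate for compound 4 is 0.003 mg/kg, within the range 0.0008 mg/kg to 0.012 mg/kg.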

Compound 4, dose for half-maximal effect: 0.0024 mg/kg
Beside the measured number, compound 4's estimate is 1.3-fold (0.10 log units) above it; the range from low to high includes it.
By their numbers in this assay, from the lowest: compounds 2 and 4 (each within the scatter of the next); then compound 1; then compound 3.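

In this assay, among these compounds, the chain itself is now read for the first time: 5-carboxypentyl in place of 5-carboxypent-1-en-1-yl, on a saturated chain carbon bound to a saturated ring carbon, gives a 1.1-fold higher number from compound 2 to compound 4 (0.04 log units; within the scatter) and so stays within the scatter. Among the compounds shown here, with the free carboxylic acid kept, this position therefore tolerates the loss of the chain's double bond without a readable change, while the only earlier step, a 100-fold higher number from compound 2 to compound 3 (2.00 log units; beyond the scatter), which replaces the acid hydrogen with ethyl, lies beyond the scatter and remains the one large effect seen in this small series. Nothing given here speaks to why the two chains read alike.

From the compounds shown here alone, whether the chain change reads the same in the ethyl ester stays open, as compound 1 and compound 3 differ in two places and so give no clean comparison. The compounds shown also leave open how far this tolerance extends, for instance to a longer chain, to a triple bond in the same stretch of chain, or to a primary amide at its end.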